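The source may hold more compounds than are shown below. What is called first, only, known or untested is meant among the compounds shown, and "the series" means these compounds.

Measured so far:
compound 1, `COC(CNc1ccccc1CO)n1cc(F)c(=O)[nH]c1=O`, 36000 nM;
compound 2, `c1ccc(Sc2ncnc3ncn(C4CNc5ccccc5CO4)c23)cc1`, 48900 nM;
compound 3, `O=c1ccn(C2COc3ccccc3CO2)c(=O)[nH]1`, 1250 nM.

In a functional assay on MCF7 cells (Homo sapiens) for antiproliferative activity (a lower number here means a stronger inhibitor, a higher number a weaker inhibitor), compound 1 gives 36000 nM, the second highest of the three numbers. Its nearest neighbour is compound 2, whose value of 48900 nM lies within the scatter of that of compound 1, so no order can be read between the two. Compound 3 stands apart: its 1250 nM is well beyond the scatter and marks it as the stronger inhibitor of the three in this assay.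

Compound 4, `COC(CN(C(=O)c1ccccc1)c1ccccc1CO)n1cc(F)c(=O)[nH]c1=O`, has not yet been measured. It differs from compound 1 in one place: benzoyl in place of hydrogen on a nitrogen on an aromatic ring. Among the measured compounds shown here, no pair among the measured compounds shows the effect of such a change, so nothing in these data anchors the direction of the step. On that basis the step of a 1.2-fold lower number from compound 1 to compound 4 (0.08 log units; within the scatter) is expected to stay within the scatter, in either direction. Compound 4 is therefore estimated at 30000 nM in this assay, with a range from 8000 nM to 110000 nM.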

Compound 4, half-maximal inhibitory concentration: 16100 nM
Beside the measured number, compound 4's estimate is 1.9-fold (0.27 log units) above it; low and high end bracket the measured number.
By their numbers in this assay, from the lowest: compound 3; then compound 4; then compounds 1 and 2 (each within the scatter of the next).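

In this assay, benzoyl in place of hydrogen on a nitrogen on an aromatic ring gives a 2.2-fold lower number from compound 1 to compound 4 (0.35 log units; beyond the scatter), a modest step and the first that can be read at this position. It shows that the hydrogen on this nitrogen can be replaced, and that a group of 8 heavy atoms carrying a six-membered aromatic ring is accepted there with no loss in this single comparison. The data offer no measured reason for the step.

From the compounds shown here alone, it remains open whether the step belongs to the carbonyl or to the aromatic ring of the benzoyl, which an acetyl or a benzyl on the same nitrogen would help to separate. Also open, going by these compounds, is whether the same change would give a similar step on a different core.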